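This account rests on a few compounds, and the source may have more. Where it says the series, first, only, none or still open, it means among the compounds named here.

Measured compounds:
- Compound 1, `CN(C)C(=O)c1cc2cnc(Nc3ccc(NC(=O)C4(C(=O)Nc5cccc(O)c5)CC4)cc3)nc2n1C1CCCC1`, giving 80.7% in a functional assay on T47D cells (Homo sapiens) for inhibition, read by CCK-8 assay, with a stated time of 72 h, tested at 1 uM; on this read-out higher numbers stand for more inhibition of growth at the one concentration tested and lower numbers for less inhibition of growth.
- Compound 2, `CN(C)C(=O)c1cc2cnc(Nc3ccc(NC(=O)C4(C(=O)Nc5ccc(O)cc5)CC4)cc3)nc2n1C1CCCC1`, giving 91.5% in this assay.

Going by the values given here, compound 2 stands highest of the two numbers in this assay; its nearest neighbour is compound 1, and the only measured step, a number 10.8 percentage points higher from compound 1 to compound 2 (beyond the scatter), is a modest one beyond the scatter, made by 4-hydroxyphenyl in place of 3-hydroxyphenyl on an amide-type nitrogen.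

Compound 3, `CN(C)C(=O)c1cc2cnc(Nc3ccc(NC(=O)C4(C(=O)Nc5ccc(Cl)cc5)CC4)cc3)nc2n1C1CCCC1`, is not yet measured. It differs from compound 2 in one place: chloro in place of hydroxy on an aromatic carbon. Among the compounds with values here, no measured step exchanges a hydroxy for a chloro on this ring; the one step known concerns only where the hydroxy sits, not its replacement, so it bears on compound 3 only loosely, by showing that changes on this ring move the growth inhibition by a modest amount. The expected step of a number 7.5 percentage points lower from compound 2 to compound 3 (within the scatter) is therefore small, more likely downward than upward, and may well lie within the scatter. Compound 3 is expected to give about 84% in this assay, with a range from 65% to 96%.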

Compound 3, percent growth inhibition at one concentration: 22.8%
Estimate against measurement, compound 3: 61.2 percentage points above, outside the stated range (below it).
By their numbers in this assay, from the lowest: compound 3; then compound 1; then compound 2.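

In this assay, chloro in place of hydroxy on the aromatic carbon para to a large group gives a number 68.7 percentage points lower from compound 2 to compound 3 (beyond the scatter), a large step, whereas moving the hydroxy gave only a number 10.8 percentage points higher from compound 1 to compound 2 (beyond the scatter). The step of a number 57.9 percentage points lower from compound 1 to compound 3 (beyond the scatter) is also large, so among these three compounds, both hydroxyphenyl amides stand well above the 4-chlorophenyl amide, and this ring is far less tolerant of the exchange of the hydroxy than the shift between the two hydroxy placements suggested. Nothing available accounts for the size of this drop.

The compounds shown leave open whether the drop follows from the hydroxy leaving or from the chloro entering: a plain phenyl, a 4-methoxyphenyl, a 4-aminophenyl or a 4-fluorophenyl on the same amide nitrogen would begin to separate the two. A 3-chlorophenyl would show whether the chloro gives the same result at the other ring position, and full concentration-response curves would show how far these single-concentration numbers reflect differences in potency.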